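The source may report more compounds than this note shows. Statements on the series, on what has been measured and on what is new or still open speak of the compounds shown alone.

Values in a functional assay on Hs-578T cells (Homo sapiens) for cytotoxicity, read by sulforhodamine B assay, with a stated time of 48 h, tested at 10 uM; a lower number here means a stronger effect, a higher number a weaker effect of the compound at the concentration tested:

compound 1 `COc1cc(-c2cc(/C=C/C(=O)c3ccc(Cl)c(Cl)c3)[nH]n2)cc(OC)c1OC`: 63%
compound 2 `COc1ccc(C(=O)/C=C/c2cc(-c3cc(OC)c(OC)c(OC)c3)n[nH]2)cc1OC`: -9%
compound 3 `COc1ccc(C(=O)/C=C/c2cc(-c3cc(OC)c(OC)c(OC)c3)n[nH]2)cc1`: 13%

Compound 3 holds the second highest of the three numbers; the nearest is compound 2, with a number 22 percentage points higher from compound 2 to compound 3 (beyond the scatter), and the furthest is compound 1, with a number 50 percentage points lower from compound 1 to compound 3 (beyond the scatter).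

Compound 4 `COc1cc(-c2cc(/C=C/C(=O)c3ccc(F)c(F)c3)[nH]n2)cc(OC)c1OC` differs from compound 3 in one place: 3,4-difluorophenyl in place of 4-methoxyphenyl on a carbonyl carbon.

Among the compounds with values here, two measured steps bear on this: a number 50 percentage points lower from compound 1 to compound 3 (beyond the scatter) and a number 72 percentage points lower from compound 1 to compound 2 (beyond the scatter), both large, both moving from 3,4-dichlorophenyl to a methoxy-bearing phenyl on the carbonyl carbon. The present change runs the other way, methoxy leaving and ring halogens entering, so a rise in this assay is expected. Since the entering group is 3,4-difluorophenyl and not 3,4-dichlorophenyl, only part of the reversal is assumed: the expected step is a number 27 percentage points higher from compound 3 to compound 4 (beyond the scatter).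

Compound 4 is estimated at 40%, with a range of 15% to 68%.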

Compound 4, a percentage reported as activity, at one concentration (the size of the read-out at that concentration, not a potency): 21%
For compound 4 the middle estimate is 19 percentage points above the measured one; the measured number falls inside the stated range.
By their numbers in this assay, from the lowest: compound 2; then compounds 3 and 4 (each within the scatter of the next); then compound 1.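

At this carbonyl carbon in this assay, a halogen-bearing phenyl does not by itself carry the high number of compound 1: 3,4-difluorophenyl in compound 4 stands well apart from 3,4-dichlorophenyl (a number 42 percentage points lower from compound 1 to compound 4 (beyond the scatter)). It is not separated from 4-methoxyphenyl (a number 8 percentage points higher from compound 3 to compound 4 (within the scatter)), though 3,4-dimethoxyphenyl remains distinct (a number 30 percentage points higher from compound 2 to compound 4 (beyond the scatter)). No available evidence explains these differences.

From the compounds shown here alone, what separates the two dihalophenyl groups stays open. Going by these compounds, how an unsubstituted phenyl, or a phenyl bearing a dimethylamino group or a carboxylic acid, would read at this carbonyl carbon also stays open.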